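A Second Hydroxy Group and Cytotoxic Potency

A few compounds are considered here, and "the series" means these few. Any claim that something is new, unique, unknown or untested is made for them only; others in the source may bear on it.

Compound 1 `O=c1cc(-c2ccc([N+](=O)[O-])cc2)oc2cc(O)ccc12` was examined in a functional assay on SK-MEL cells (Homo sapiens) for cytotoxicity, read by MTT assay, with a stated time of 6 days; on this read-out lower numbers stand for an effect already at smaller amounts and higher numbers for an effect only at larger amounts of compound. For compound 1 the result is only a limit of the assay, > 25 ug/mL. Compound 2 `O=c1cc(-c2ccc([N+](=O)[O-])cc2)oc2c(O)c(O)ccc12`, tested in this assay, gives 3.29 ug/mL. The change from compound 1 to compound 2 is hydroxy in place of hydrogen on an aromatic carbon, and it produced an at least 7.5-fold lower number from compound 1 to compound 2 (0.88 log units; beyond the scatter). Compound 3 `COc1cc(-c2cc(=O)c3ccc(O)cc3o2)cc(OC)c1OC` differs from compound 1 in more than one place; the difference between the two cores is not broken down here. In this assay compound 3 also gives only a limit, > 25 ug/mL. Two of the three results thus sit at the limit of > 25 ug/mL in this assay, at which 2 of the 3 values shown sit. Compound 4 `COc1cc(-c2cc(=O)c3ccc(O)c(O)c3o2)cc(OC)c1OC` has not yet been measured. It relates to compound 3 by hydroxy in place of hydrogen on an aromatic carbon, the same change that turned compound 1 into compound 2, at the same place. A step of an at least 4.1-fold lower number from compound 3 to compound 4 (0.61 log units; beyond the scatter) is expected because an at least 7.5-fold lower number from compound 1 to compound 2 (0.88 log units; beyond the scatter) followed this same change. Since compound 3 starts at a limit, the expectation is loose. Compound 4 is accordingly expected to give about 6 ug/mL, between 1.5 ug/mL and 25 ug/mL.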

Compound 4, concentration for half-maximal effect: > 25 ug/mL
Compound 4: only a limit was reported (the forecaster's own chance of this, stated with the estimate: 35%); at least 4.1-fold (0.61 log units) between middle value and limit.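

In this assay compound 4 gives only a limit, > 25 ug/mL. Compound 3 is also reported only as a limit, and the step between compound 3 and compound 4 cannot be read: the limit of > 25 ug/mL in this assay, at which 3 of the 4 values shown sit. The compounds shown leave open whether hydroxy in place of hydrogen lowers the number on the core of compound 3 as it does on the core of compound 1.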